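This account rests on a few compounds, and the source may have more. Where it says the series, first, only, none or still open, it means among the compounds named here.

Measured compounds:
compound 1 `O=C(Nc1ccc(-n2ncc3c(C(F)(F)F)cccc32)cc1)Nc1ccc(Cl)c(C(F)(F)F)c1`, 2900 nM in a functional assay on HT-29 cells (Homo sapiens) for cytotoxicity, read by MTT assay, with a stated time of 72 h; on this read-out lower numbers stand for stronger inhibition and higher numbers for weaker inhibition
compound 2 `Cc1cccc2c1cnn2-c1ccc(NC(=O)Nc2ccc(Cl)c(C(F)(F)F)c2)cc1`, 32000 nM in this assay

Compound 1 stands lowest of the two numbers in hand; its nearest neighbour is compound 2, with an 11-fold higher number from compound 1 to compound 2 (1.04 log units; beyond the scatter). For the measured compounds named here, that single step changes the substituent on the aromatic carbon of the shared core and is the only step so far.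

Compound 3 `O=C(Nc1ccc(-n2ncc3c(C(F)(F)F)cccc32)cc1)Nc1ccc(C(F)(F)F)cc1` is not yet measured. It differs from compound 1 by 4-(trifluoromethyl)phenyl in place of 4-chloro-3-(trifluoromethyl)phenyl on an amide-type nitrogen. Going by the values given here, no measured step touches this urea-side aryl, so the step from compound 1 to compound 2 does not bear directly on the change; it shows only that one substituent swap moved the number far beyond the scatter. With nothing measured on the relevant side, the expectation rests on the loss of chlorine alone and is worded with caution: a modest rise in the number for compound 3 is expected, a 2.1-fold higher number from compound 1 to compound 3 (0.32 log units; beyond the scatter), though a step within the scatter cannot be excluded. The estimate for compound 3 is 6000 nM, with a range from 2000 nM to 20000 nM.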

Compound 3, half-maximal inhibitory concentration: 3300 nM
Compound 3: middle estimate off by 1.8-fold (0.26 log units), on the high side; the measured number falls inside the stated range.
By their numbers in this assay, from the lowest: compounds 1 and 3 (each within the scatter of the next); then compound 2.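

In this assay, for the compounds shown here, 4-(trifluoromethyl)phenyl in place of 4-chloro-3-(trifluoromethyl)phenyl on an amide-type nitrogen gives a 1.1-fold higher number from compound 1 to compound 3 (0.06 log units; within the scatter), the first reading of this position, and here the swap leaves the two numbers indistinguishable. The aryl group on this nitrogen can therefore lose its chlorine and take the other trifluoromethyl pattern without a measurable shift, whereas the methyl-for-trifluoromethyl swap on the shared core gave an 11-fold higher number from compound 1 to compound 2 (1.04 log units; beyond the scatter), so the series now holds one step beyond the scatter and one within it. No measurement on hand accounts for either outcome.

The step alters two features at once, as the two group names show, so the separate contributions of the chlorine and of the placement of the trifluoromethyl cannot be read from it, and the flat result could hide opposing contributions. Also open, as far as these compounds go, is how this position responds to groups of a different kind, such as a carboxylic acid, an amine or a methoxy group on the phenyl ring, and whether the effect of the methyl swap on the core holds with 4-(trifluoromethyl)phenyl on the amide-type nitrogen.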